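The source may hold more compounds than are shown below. What is called first, only, known or untested is meant among the compounds shown, and "the series" means these compounds.

Compound 1 `CC(Sc1nc2c(cnn2C)c(=O)n1-c1ccccc1)c1ccccn1` in an assay on isolated protein for inhibition of aldehyde dehydrogenase 1A1 (Homo sapiens); on this read-out higher numbers stand for weaker inhibition and lower numbers for stronger inhibition: 242 nM
Compound 2 `COc1cccc(C(C)Sc2nc3c(cnn3C)c(=O)n2-c2ccccc2)c1`: 451 nM
Compound 3 `COc1ccc(C(C)Sc2nc3c(cnn3C)c(=O)n2-c2ccccc2)cc1`: 352 nM

These three compounds share one core and differ only in the aromatic group that sits on a saturated chain carbon bound to a saturated chain carbon and a sulfur. In this assay compound 3 gives 352 nM, a number that lies within the scatter of both companions: a 1.5-fold higher number from compound 1 to compound 3 (0.16 log units; within the scatter), and a 1.3-fold lower number from compound 2 to compound 3 (0.11 log units; within the scatter). Compound 4 `CC(Sc1nc2c(cnn2C)c(=O)n1-c1ccccc1)c1cncnc1` has not yet been tested. It carries pyrimidin-5-yl in place of 4-methoxyphenyl on a saturated chain carbon bound to a saturated chain carbon and a sulfur. The measured steps that bear on this are the exchanges of one aromatic group for another at the same place: a 1.9-fold higher number from compound 1 to compound 2 (0.27 log units; within the scatter), a 1.5-fold higher number from compound 1 to compound 3 (0.16 log units; within the scatter) and a 1.3-fold lower number from compound 2 to compound 3 (0.11 log units; within the scatter). Each of them stayed within the scatter, including the steps that traded a ring with hetero atoms for a ring of carbon only. On that basis the move to pyrimidin-5-yl is expected to leave this assay essentially unchanged, with no step beyond the scatter in either direction. For compound 4 the expected value is 300 nM, with a range from 130 nM to 700 nM. This estimate amounts to an expected 1.2-fold lower number from compound 3 to compound 4 (0.07 log units; within the scatter).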

Compound 4, half-maximal inhibitory concentration: 94 nM
Compound 4: the middle estimate sits 3.2-fold (0.50 log units) above what was measured; measured number outside the range, below it.
By their numbers in this assay, from the lowest: compound 4; then compounds 1, 3 and 2 (each within the scatter of the next).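

In this assay this position proves sensitive to which aromatic group it carries: there is a 3.7-fold lower number from compound 3 to compound 4 (0.57 log units; beyond the scatter), a 4.8-fold lower number from compound 2 to compound 4 (0.68 log units; beyond the scatter) and a 2.6-fold lower number from compound 1 to compound 4 (0.41 log units; beyond the scatter), which makes compound 4 the strongest inhibitor of the four. The earlier exchanges among pyridin-2-yl, 3-methoxyphenyl and 4-methoxyphenyl all stayed within the scatter, so a ring with a hetero atom is not enough by itself, since compound 1 carries one and still gives a higher number than compound 4, and the loss of methoxy is not enough either, since compound 1 has none. No measurement shown here explains why pyrimidin-5-yl stands apart from the other groups.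

Pyrimidin-5-yl differs from pyridin-2-yl both in the number of ring nitrogen atoms and in their arrangement, and these four compounds cannot separate the two. As far as these compounds go, it also remains open how a plain phenyl, a pyridin-3-yl or a pyrazin-2-yl would behave at this place, and whether the gain would survive if the methyl group on the same saturated chain carbon were replaced by an ethyl group.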